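Ester Variation on a Shared Core in PC-3 Cells

The source may hold more compounds than are shown below. What is called first, only, known or untested is meant among the compounds shown, and "the series" means these compounds.

Compound 1 `COc1ccc(C(=O)Oc2cc3c(cc2C)[C@@H](C(C)C)CC=C3C)cc1`: 60.6%
Compound 2 `COc1ccc(C(=O)Oc2cc3c(C)ccc(C(C)C)c3cc2C)cc1`: 10.4%

In a functional assay on PC-3 cells (Homo sapiens) for antiproliferative activity, read by sulforhodamine B assay, with a stated time of 48 h, tested at 50 uM (on this read-out lower numbers stand for less inhibition and higher numbers for more inhibition at the one concentration tested (going by the name of the read-out)), compound 1 gives 60.6%, the higher of the two numbers shown, while compound 2 gives 10.4%, a gap that lies beyond the usual scatter. Compound 3 `CC1=CC[C@H](C(C)C)c2cc(C)c(OC(=O)c3cccc([N+](=O)[O-])c3)cc21` keeps the core of compound 1 and differs from it only in the ester part: 3-nitrophenyl in place of 4-methoxyphenyl on a carbonyl carbon. Among the measured compounds shown here, no measured pair follows this change, so its effect is uncertain; the step from compound 1 to compound 3 is expected to be small and downward, a number 10.6 percentage points lower from compound 1 to compound 3 (beyond the scatter), possibly within the scatter. Compound 3 is therefore estimated at 50%, with a range from 25% to 75%.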

Compound 3, a percentage reported as inhibition, at one concentration (the size of the read-out at that concentration, not a potency): 36.9%
Estimate against measurement, compound 3: 13.1 percentage points above, and the stated range covers the measured number.
By their numbers in this assay, from the lowest: compound 2; then compound 3; then compound 1.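

In this assay, among the compounds shown here, the ester part proves to count on the core of compound 1: 3-nitrophenyl in place of 4-methoxyphenyl on a carbonyl carbon gives a number 23.7 percentage points lower from compound 1 to compound 3 (beyond the scatter), a modest step and the first single-place change that can be read here. Compound 3 still shows inhibition at the one concentration tested, so this change lowers the number without removing it. Nothing at hand bears on why the number falls.

On these data alone, whether the step comes from losing 4-methoxyphenyl or from gaining 3-nitrophenyl stays open. So does what a plain phenyl, a 4-nitrophenyl or an acetyl ester would give on this core.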